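The source may report more compounds than this note shows. Statements on the series, on what has been measured and on what is new or still open speak of the compounds shown alone.

Measured in an ADME assay on a cell-free system (plasma, Rattus norvegicus) for protein binding; a higher number here means a larger unbound share of the compound, a lower number a smaller unbound share:
Compound 1 `COCC(C1CC1)n1c(=O)c(C)nc2c(-c3cc(F)c(OC)cc3Cl)ncnc21`: 0.028
Compound 2 `CCC(C1CC1)n1c(=O)c(C)nc2c(-c3cc(Cl)c(OC(F)F)cc3C)ccnc21`: 0.003
Compound 3 `CC[C@H](COC)n1c(=O)c(C)nc2c(-c3ccc(Cl)cc3Cl)ncnc21`: 0.022

Compound 3 lies within the scatter of compound 1 and beyond the scatter above compound 2. Compound 4 `CC[C@@H](C1CC1)n1c(=O)c(C)nc2c(-c3ccc(Cl)cc3Cl)ncnc21` has yet to be measured in this assay. It differs from compound 3 by 1-cyclopropylpropyl in place of 1-(methoxymethyl)propyl on an aromatic nitrogen. Among the compounds with values here, no measured pair isolates this change. Compound 2 also carries 1-cyclopropylpropyl and gives 0.003, but it differs elsewhere too, so only a moderate fall in the unbound share is expected. The expected change is a 2.4-fold lower number from compound 3 to compound 4 (0.39 log units; beyond the scatter). For compound 4 the estimated value is 0.009, with an expected range from 0.004 to 0.018.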

Compound 4, unbound fraction: 0.004
The estimate for compound 4 lay 2.3-fold (0.35 log units) above the measured number; the range from low to high includes it.
By their numbers in this assay, from the lowest: compounds 2 and 4 (each within the scatter of the next); then compounds 3 and 1 (each within the scatter of the next).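

In this assay, placing 1-cyclopropylpropyl instead of 1-(methoxymethyl)propyl on the aromatic nitrogen gives a 5.5-fold lower number from compound 3 to compound 4 (0.74 log units; beyond the scatter) with the rest of the molecule unchanged, so this position alone can shift the unbound share. The change removes a hydrogen-bond acceptor and adds a three-membered ring at once, and this single step does not separate the two. Nothing available here accounts for the fall.

On these data alone, it remains open whether the same change gives a similar step on other substituted cores. The compounds shown also leave open how an amine or a carboxylic acid on this chain would read.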